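Amide side chain: diethylamino to dimethylamino

The compounds below may be only part of what the source reports. "The series", "measured", "known", "first", "only" and "open" are said of these compounds alone.

In a functional assay on Caco-2 cells (Homo sapiens), read by MTT assay, with a stated time of 48 h (on this read-out lower numbers stand for stronger inhibition and higher numbers for weaker inhibition), the measured compounds read:
- compound 1 `CCOC(=O)CN(C)C(=O)c1ccc(C(CC)(CC)c2ccc(OCC(O)C(C)(C)C)c(C)c2)n1CC` gives 12200 nM
- compound 2 `CCN(CC)CCNC(=O)c1ccc(C(CC)(CC)c2ccc(OCC(O)C(C)(C)C)c(C)c2)n1CC` gives 2310 nM

Compound 2 holds the lower of the two numbers, at 2310 nM in this assay and serves as the reference for the next comparison. Compound 3 `CCn1c(C(=O)NCCN(C)C)ccc1C(CC)(CC)c1ccc(OCC(O)C(C)(C)C)c(C)c1` has dimethylamino in place of diethylamino on a saturated chain carbon, two bonds along the chain from an amide-type nitrogen. Among the measured compounds shown here, only one measured step bears on this, and only indirectly. That step is a 5.3-fold lower number from compound 1 to compound 2 (0.72 log units; beyond the scatter) and it is modest but beyond the scatter. It exchanges the whole group on the carbonyl carbon, with (2-(diethylamino)ethyl)amino in place of ((ethoxycarbonyl)methyl)(methyl)amino. For the measured compounds named here, no measured pair tests diethylamino against dimethylamino alone. The present change is narrower than that exchange, so a smaller step is expected, probably within the scatter and with at most a slight lean towards a higher number (a 1.2-fold higher number from compound 2 to compound 3 (0.08 log units; within the scatter)). The estimated value for compound 3 is 2800 nM (expected range 1200 nM to 6500 nM).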

Compound 3, half-maximal inhibitory concentration: 1300 nM
Compound 3: middle estimate off by 2.2-fold (0.33 log units), on the high side, and the stated range covers the measured number.
By their numbers in this assay, from the lowest: compounds 3 and 2 (each within the scatter of the next); then compound 1.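

In this assay the direct comparison of dimethylamino with diethylamino on a saturated chain carbon, two bonds along the chain from an amide-type nitrogen, gives a 1.8-fold lower number from compound 2 to compound 3 (0.25 log units; within the scatter) and so does not separate the two groups; the loss of two carbons from this amine leaves the reading indistinguishable in this assay. The wider exchange on the carbonyl carbon gives a 9.4-fold lower number from compound 1 to compound 3 (0.97 log units; beyond the scatter) and thus shows that (2-(dimethylamino)ethyl)amino, like (2-(diethylamino)ethyl)amino, stands clear of the ((ethoxycarbonyl)methyl)(methyl)amino group of compound 1, so the separation from compound 1 does not depend on which of these two amines ends the chain. Nothing on hand accounts for these numbers or for the separation from compound 1.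

Still open, going by these compounds, is whether a ring amine such as pyrrolidine or morpholine in place of dimethylamino, or a longer chain between the amide-type nitrogen and the amine, would move the number beyond the scatter. Also open, on these data alone, is how a carboxylic acid in place of the ethyl ester of compound 1 would read, and whether a primary amine at the chain end would hold the level of compound 2 and compound 3.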